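Shortening the link to the oxazolidinedione ring

The source may hold more compounds than are shown below. What is called first, only, known or untested is meant among the compounds shown, and "the series" means these compounds.

Compound 1 `CC(C)[C@H](C[C@H]1OC(=O)NC1=O)c1ccc(-c2ccc3cccc(F)c3c2)[nH]c1=O`: 0.95 h
Compound 2 `CCC(CC)C(/C=C1\OC(=O)NC1=O)c1ccc(-c2ccc3cccc(F)c3c2)[nH]c1=O`: > 3 h

Among the compounds with values here, in an ADME assay on microsomes from liver (Rattus norvegicus) for metabolic stability (a lower number here means that the compound disappears faster, a higher number that the compound lasts longer), compound 1 gives 0.95 h, the only plain number among the two values. Compound 2 stops at > 3 h, which is a limit of the assay rather than a number (the limit of > 3 h in this assay, at which 1 of the 2 values shown sits). Compound 3 `CC(C)[C@@H](c1ccc(-c2ccc3cccc(F)c3c2)[nH]c1=O)[C@H]1OC(=O)NC1=O` differs from compound 1 by 2,4-dioxo-1,3-oxazolidin-5-yl in place of (2,4-dioxo-1,3-oxazolidin-5-yl)methyl on a saturated chain carbon bound to an aromatic carbon and a saturated chain carbon. Within the data shown here, no measured step covers a change of this kind, and compound 2 resting at a limit gives no direction. The step is therefore expected to be small, a 1.1-fold higher number from compound 1 to compound 3 (0.02 log units; within the scatter), within the usual scatter. Compound 3 is estimated at 1 h, between 0.5 h and 2.5 h.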

Compound 3, half-life: 1.93 h
Estimate against measurement, compound 3: 1.9-fold (0.29 log units) below; the measured number falls inside the stated range.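

Replacing (2,4-dioxo-1,3-oxazolidin-5-yl)methyl with 2,4-dioxo-1,3-oxazolidin-5-yl on this saturated chain carbon gives a readable step in this assay: a 2.0-fold higher number from compound 1 to compound 3 (0.31 log units; beyond the scatter). The step is modest, yet it shows that the shorter link does not shorten the half-life at this position. Nothing shown accounts for the step.

From the compounds shown here alone, whether an amine or a carboxylic acid in place of the 2,4-dioxo-1,3-oxazolidin-5-yl would lengthen or shorten the half-life stays open. Compound 2 remains a limit of the assay and offers no comparison: the limit of > 3 h in this assay, at which 1 of the 3 values shown sits.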